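The source may hold more compounds than are shown below. What is called first, only, known or untested is meant among the compounds shown, and "the series" means these compounds.

Working notes on the series.

Compound 1 `CCCN(CC[C@H]1CC[C@H](NC(=O)/C=C/c2ccc(Cl)cc2)CC1)[C@H]1CCc2nc(N)sc2C1` is the reference. In an assay on brain for displacement of a labelled ligand from D(3) dopamine receptor (Rattus norvegicus) (on this read-out higher numbers stand for weaker inhibition and lower numbers for stronger inhibition), compound 1 gives 2.5 nM. Within the data shown here, its only measured neighbour is compound 2 `CCCN(CC[C@H]1CC[C@H](NC(=O)c2ccc(-c3noc(C)n3)cc2)CC1)[C@H]1CCc2nc(N)sc2C1`, which in this assay gives 1.3 nM; the step of a 1.9-fold lower number from compound 1 to compound 2 (0.28 log units; within the scatter) exchanged the group on the carbonyl carbon and left the number where it was. Compound 1 thus holds the highest of the two numbers, but the gap to compound 2 is within the scatter, so no ordering is claimed.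

Compound 3 `CCCN(CC[C@H]1CC[C@H](NS(=O)(=O)c2cccc(C)c2)CC1)[C@H]1CCc2nc(N)sc2C1` is not yet measured. It differs from compound 1 in one place: (3-methylphenyl)sulfonyl in place of (2-(4-chlorophenyl)ethenyl)carbonyl on an amine nitrogen. Among the measured compounds shown here, the one measured step bears only loosely on this change, because a 1.9-fold lower number from compound 1 to compound 2 (0.28 log units; within the scatter) kept the carbonyl and varied the aryl part, whereas here the carbonyl itself is replaced by a sulfonyl. For the measured compounds named here, no measured pair covers an amide-to-sulfonamide exchange, so the direction is uncertain; a moderate rise in the number is expected, with wide bounds.

For compound 3 in this assay the expected value is 8 nM, with a range from 2 nM to 40 nM, which means an expected step of a 3.2-fold higher number from compound 1 to compound 3 (0.51 log units; beyond the scatter).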

Compound 3, inhibition constant: 0.89 nM
Compound 3: middle estimate off by 9.0-fold (0.95 log units), on the high side; the measured number lies below the stated range.
By their numbers in this assay, from the lowest: compounds 3, 2 and 1 (each within the scatter of the next, the first and the last beyond it).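

In this assay, among these compounds, the amine nitrogen on the saturated ring carbon accepts a sulfonyl as well as a carbonyl: a 2.8-fold lower number from compound 1 to compound 3 (0.45 log units; beyond the scatter), the first step to lie beyond the scatter, though it is a modest one. Compound 3 carries no carbonyl at this place, so a carbonyl is not required for a low number here, and compound 2 at 1.3 nM and compound 3 at 0.89 nM stand within the scatter of each other, which puts the amide of compound 2 and the sulfonamide of compound 3 on the same level. No evidence is at hand that accounts for the step from compound 1 to compound 3.

The linking group and the aryl part change together in this step, so the share of the sulfonyl and the share of the 3-methylphenyl group cannot be separated. Also open, from the compounds shown here alone, is how this assay would read for a urea at the same nitrogen, for a methylsulfonyl group in place of the arylsulfonyl, or for the free amine.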